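A few compounds are considered here, and "the series" means these few. Any claim that something is new, unique, unknown or untested is made for them only; others in the source may bear on it.

Working notes on the series. Compound 1 `CCCc1c(COc2ccc(C(=O)C(C)(C)Cc3nnn[nH]3)cc2)ccc(C(C)=O)c1O` is measured in a functional assay on ileum (Cavia porcellus) with cysteinyl leukotriene receptor (Homo sapiens) as the target (a higher number here means a more potent compound, by a factor of ten per unit of this negative logarithm, a lower number a less potent compound), where compound 1 gives 6.93. Compound 2 `CCCCc1c(COc2ccc(C(=O)CCCCC(=O)O)cc2)ccc(C(C)=O)c1O` has been measured as well and in this assay compound 2 gives 7.28, which leaves compound 1 the lower of the two numbers, a gap beyond the scatter. Compound 3 `CCCc1c(COc2ccc(C(=O)CCCCCCc3nnn[nH]3)cc2)ccc(C(C)=O)c1O` is not yet measured; it differs from compound 1 by 6-(1H-tetrazol-5-yl)hexyl in place of 1-((1H-tetrazol-5-yl)methyl)-1-methylethyl on a carbonyl carbon. Going by the values given here, no measured pair isolates this change, so the direction rests on the two values alone: compound 2, which also carries a longer unbranched chain on the carbonyl carbon, gives 7.28, and a modest gain is expected, a number 0.27 log units higher from compound 1 to compound 3 (within the scatter). Compound 3 is therefore estimated at 7.2, within 6.6 to 7.8.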

Compound 3, negative logarithm of the antagonist equilibrium constant: 7.33
Compound 3: the middle estimate sits 0.13 log units below what was measured; low and high end bracket the measured number.
By their numbers in this assay, from the lowest: compound 1; then compounds 2 and 3 (each within the scatter of the next).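

Going by these compounds alone, on the carbonyl carbon, 6-(1H-tetrazol-5-yl)hexyl in place of 1-((1H-tetrazol-5-yl)methyl)-1-methylethyl gives, in this assay, a number 0.40 log units higher from compound 1 to compound 3 (beyond the scatter), the only step read at this position. Both groups carry the tetrazole, so the step reflects a change in the chain linking it to the carbonyl carbon, and the number at this position responds to that chain. Nothing available explains the step. Open, on these data alone, is how a longer chain ending in the same tetrazole would read here. Also open, as far as these compounds go, is whether a carboxylic acid in place of the tetrazole on the hexyl chain would keep this number.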